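The source may report more compounds than this note shows. Statements on the series, on what has been measured and on what is new or still open speak of the compounds shown alone.

Compound 1, `Nc1nc(N)c2c(-c3cc4ccccc4o3)cn([C@@H]3O[C@H](CO)[C@@H](O)[C@H]3O)c2n1`: 78500 nM
Compound 2, `O=c1[nH]cnc2c1c(-c1cc3ccccc3o1)cn2[C@@H]1O[C@H](CO)[C@@H](O)[C@H]1O`: > 100000 nM
Compound 3, `Cc1ncnc2c1c(-c1ccoc1)cn2[C@@H]1O[C@H](CO)[C@@H](O)[C@H]1O`: 98300 nM

All three compounds were run in an ADME assay on MRC5 cells (Homo sapiens), read by MTT assay, with a stated time of 72 h; on this read-out higher numbers stand for weaker inhibition and lower numbers for stronger inhibition. Compound 1 gives 78500 nM and compound 3 gives 98300 nM, and these two values lie within the scatter of each other. For compound 2 this assay reports only a limit, > 100000 nM, which is the limit of > 100000 nM in this assay, at which 1 of the 3 values shown sits. Compound 2 therefore stands at the weak end of the values shown, without a number of its own. Compound 4, `O=c1[nH]cnc2c1c(-c1ccccc1)cn2[C@@H]1O[C@H](CO)[C@@H](O)[C@H]1O`, differs from compound 2 in one place: phenyl in place of 1-benzofuran-2-yl on an aromatic carbon. Among the measured compounds shown here, no measured pair isolates this change, so no step size is known from the data. Compound 4 is expected to remain near the limit, with the step of a number no higher from compound 2 to compound 4 (the limit leaves the size open) expected to stay within the scatter. The estimate for compound 4 is 100000 nM, between 50000 nM and 200000 nM.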

Compound 4, half-maximal inhibitory concentration: > 100000 nM
Compound 4 was reported as a limit (the forecaster's own chance of this, stated with the estimate: 65%); the middle value sits exactly at the limit.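

Compound 2 and compound 4 both stand at a limit in this assay, and no step can be read between them. The compounds shown leave open whether phenyl and 1-benzofuran-2-yl differ at all here.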